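The source may report more compounds than this note shows. Statements on the series, on what has been measured and on what is new or still open speak of the compounds shown alone.

Measured compounds:

Compound 1, `CC(=O)c1ccc(Nc2ccnc(SCC(=O)c3ccc(Br)cc3)n2)cc1`: 30%
Compound 2, `CCOC(=O)c1ccc(Nc2ccnc(SCC(=O)c3ccc([N+](=O)[O-])cc3)n2)cc1`: 37%
Compound 3, `CCOC(=O)c1ccc(Nc2ccnc(SCC(=O)c3ccc(C#N)cc3)n2)cc1`: 49%

All three were tested in a functional assay on K562 cells (Homo sapiens) for inhibition, read by sulforhodamine B assay, with a stated time of 48 h, tested at 10 uM; on this read-out lower numbers stand for less inhibition of growth and higher numbers for more inhibition of growth at the one concentration tested. Compound 1 holds the smallest of the three numbers, but compound 2 sits within the usual scatter of it, so the two cannot be told apart; only compound 3 lies beyond the scatter above compound 1. Going by the values given here, the one step between compounds that differ in a single place is a number 12 percentage points higher from compound 2 to compound 3 (beyond the scatter). That step concerns the exchange of one small group for another at the same position where compound 1 carries its bromo, but neither of the groups involved is bromo or phenyl, so it does not bear directly on the change considered here.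

Compound 4, `CC(=O)c1ccc(Nc2ccnc(SCC(=O)c3ccc(-c4ccccc4)cc3)n2)cc1`, is not yet measured. It differs from compound 1 by phenyl in place of bromo on an aromatic carbon. Among the compounds with values here, no measured step covers this exchange, so the expectation can rest only on compound 1 itself. In the absence of evidence either way, no step beyond the scatter is expected: compound 4 is estimated at 35%, within a range from 15% to 55%. This estimate corresponds to an expected step of a number 5 percentage points higher from compound 1 to compound 4 (within the scatter).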

Compound 4, percent growth inhibition at one concentration: 10%
The estimate for compound 4 lay 25 percentage points above the measured number; the measured number lies below the stated range.
By their numbers in this assay, from the lowest: compound 4; then compounds 1 and 2 (each within the scatter of the next); then compound 3.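

In this assay, phenyl in place of bromo on an aromatic carbon gives a number 20 percentage points lower from compound 1 to compound 4 (beyond the scatter), which shows that the number at this position can fall beyond the scatter when the group there changes. The earlier step, a number 12 percentage points higher from compound 2 to compound 3 (beyond the scatter), exchanged cyano for nitro and gave a rise, so the two steps together show that changes at this position can move the number either way, although they were measured on compounds that differ elsewhere. The new step also replaces a single bromine atom with a group of six carbon atoms carrying a ring of its own, but nothing available explains why the number falls.

On these data alone, with only bromo and phenyl compared directly, it remains open whether the drop follows from the ring itself or from the number of atoms added, and a methyl group, a methoxy group, a cyclohexyl ring or a pyridine ring at the same place could help separate these readings. As far as these compounds go, it is also open whether an amine or a carboxylic acid there would be tolerated, and whether phenyl would lower the number in the same way in compounds carrying the ethyl ester.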